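The source may report more compounds than this note shows. Statements on the series, on what has been measured and on what is new or still open speak of the compounds shown alone.

The measured compounds and their values:

compound 1, `COc1ccccc1N1CCN(CCn2c(=O)[nH]c3[nH]c(-c4ccccc4)cc3c2=O)CC1`, 1.99 nM
compound 2, `O=c1[nH]c2[nH]c(-c3ccccc3)cc2c(=O)n1CCN1CCN(c2ccccc2Cl)CC1`, 4.71 nM
compound 3, `COc1ccccc1N1CCN(CCn2c(=O)[nH]c3[nH]c(-c4ccccc4C)cc3c2=O)CC1`, 1.19 nM

All three were tested in an assay on isolated protein for binding affinity to Adrenergic receptor alpha-1 (Homo sapiens); a lower number here means a stronger inhibitor, a higher number a weaker inhibitor. Compound 3 gives the lowest number of the three, yet its gap to compound 1, a 1.7-fold lower number from compound 1 to compound 3 (0.22 log units; within the scatter), is within the scatter, so these two cannot be told apart on the evidence. Compound 2, with a value of 4.71 nM, is the only one that sits clearly apart.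

Compound 4, `COc1ccccc1N1CCN(CCn2c(=O)[nH]c3[nH]c(-c4ccc(C)cc4)cc3c2=O)CC1`, has not yet been measured. It differs from compound 3 by 4-methylphenyl in place of 2-methylphenyl on an aromatic carbon: the same atoms, with the methyl moved to another carbon of the same phenyl ring.

For the measured compounds named here, only one measured step touches this phenyl ring, the addition of the methyl: a 1.7-fold lower number from compound 1 to compound 3 (0.22 log units; within the scatter), a change within the scatter. The other step, a 2.4-fold higher number from compound 1 to compound 2 (0.37 log units; beyond the scatter), concerns a different ring and was modest. Going by the values given here, no measured pair shows what moving the methyl around the phenyl ring does, so there is no basis for expecting a shift beyond the scatter in this assay. The expected step is a 1.5-fold higher number from compound 3 to compound 4 (0.18 log units; within the scatter). Compound 4 is therefore estimated at 1.8 nM, with a range from 0.7 nM to 5 nM.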

Compound 4, inhibition constant: 4.97 nM
Compound 4: the middle estimate sits 2.8-fold (0.44 log units) below what was measured; the measured number falls inside the stated range.
By their numbers in this assay, from the lowest: compounds 3 and 1 (each within the scatter of the next); then compounds 2 and 4 (each within the scatter of the next).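

In this assay, moving a single methyl around the phenyl ring gives a 4.2-fold higher number from compound 3 to compound 4 (0.62 log units; beyond the scatter), so with the same atoms, this ring is sensitive to where the methyl sits and not only to whether one is present. Adding the methyl as 4-methylphenyl gives a 2.5-fold higher number from compound 1 to compound 4 (0.40 log units; beyond the scatter), whereas adding it as 2-methylphenyl gives a 1.7-fold lower number from compound 1 to compound 3 (0.22 log units; within the scatter), so among these compounds only the 4-methylphenyl form separates from the plain phenyl of compound 1. The data shown offer no measured explanation for this difference.

The compounds shown leave open where 3-methylphenyl would fall, and whether a methoxy group, a chlorine atom or an amine in the place the methyl holds in 4-methylphenyl would give a similar number. They also leave open whether moving the methyl has the same effect when the methoxy group of compound 3 and compound 4 is replaced by the chlorine atom carried by compound 2.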